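A tert-Butyl Group Tried on a Second Core

The source may hold more compounds than are shown below. What is called first, only, known or untested is meant among the compounds shown, and "the series" means these compounds.

All four compounds here were tested, or are to be tested, in a functional assay on PC-3 cells (Homo sapiens) for cytotoxicity, read by sulforhodamine B assay, tested at 10 uM; on this read-out higher numbers stand for more inhibition at the one concentration tested (going by the name of the read-out) and lower numbers for less inhibition. Compound 2 `CC(=O)OC[C@H]1O[C@@H](n2cc(-c3cc(-c4ccccc4)no3)c(=O)[nH]c2=O)C[C@@H]1OC(C)=O` gives 85.5% in this assay. Compound 1 `CC(=O)OC[C@H]1O[C@@H](n2cc(-c3cc(-c4ccc(C(C)(C)C)cc4)no3)c(=O)[nH]c2=O)C[C@@H]1OC(C)=O` differs from it in one place, (tert-butyl in place of hydrogen on an aromatic carbon), and in this assay compound 1 gives 27.5%. That single change made a large step: a number 58 percentage points lower from compound 2 to compound 1 (beyond the scatter).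

Compound 3 `CC(=O)OC[C@H]1O[C@@H](n2cc(-c3cn(Cc4ccccc4)nn3)c(=O)[nH]c2=O)C[C@@H]1OC(C)=O` carries a different core; how the two cores differ is not broken down here. In this assay compound 3 gives 92.1%, a value that lies within the usual scatter of that of compound 2, so the two cannot be put in order.

Compound 4 `CC(=O)OC[C@H]1O[C@@H](n2cc(-c3cn(Cc4ccc(C(C)(C)C)cc4)nn3)c(=O)[nH]c2=O)C[C@@H]1OC(C)=O` has not yet been measured. It stands to compound 3 as compound 1 stands to compound 2, carrying (tert-butyl in place of hydrogen on an aromatic carbon). Both place descriptions read the same, so this is the same change seen once already. The step is expected to be a number 54.1 percentage points lower from compound 3 to compound 4 (beyond the scatter), because the same change earlier gave a number 58 percentage points lower from compound 2 to compound 1 (beyond the scatter). The cores differ and that difference is not broken down. The carry-over is therefore uncertain, and the range is set wide. For compound 4 in this assay the expected value is 38%, with an estimated range from 15% to 70%.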

Compound 4, a percentage reported as inhibition, at one concentration (the size of the read-out at that concentration, not a potency): 90.4%
Compound 4: middle estimate off by 52.4 percentage points, on the low side; the measured number lies above the stated range.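

On the core of compound 3, tert-butyl in place of hydrogen on an aromatic carbon gives a number 1.7 percentage points lower from compound 3 to compound 4 (within the scatter) in this assay, so the large loss seen on the core of compound 2 does not reappear here. Placed side by side, the two steps show that the same change does not have the same effect on these two cores, and that a step measured on one of them cannot simply be transferred to the other: the same change on two cores in this assay, a number 58 percentage points lower (beyond the scatter) from compound 2 to compound 1 and a number 1.7 percentage points lower (within the scatter) from compound 3 to compound 4, 56.3 percentage points apart, beyond the scatter of two such steps What this does not show is which feature of the cores separates the two results, why the results part, or how the change would behave on any third core, since two pairs of compounds tested at a single concentration can establish only that the difference exists.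

The compounds shown leave open what a group other than tert-butyl, such as methyl, an amine or a carboxylic acid, would do at the same place on the six-membered aromatic ring of each core. For the compounds shown here, whether such groups would also separate the two cores, or whether the split is seen only with tert-butyl, remains to be tested.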